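Toward an isopropoxyphenyl analogue in a cytotoxicity assay

The source may hold more compounds than are shown below. What is called first, only, known or untested is meant among the compounds shown, and "the series" means these compounds.

Compound 1 `CC(C)N(Cc1cccc(OCCCCCC(=O)O)c1)C(=O)c1ccc(-c2cccc3ccccc23)cc1` gives > 26000 nM in an ADME assay on HEK293 cells (Homo sapiens) for cytotoxicity, read by CellTiter-Glo and resazurin assay, with a stated time of 72 h (on this read-out higher numbers stand for an effect only at larger amounts of compound and lower numbers for an effect already at smaller amounts), and this is a limit of the assay.
Compound 2 `CC(C)N(Cc1cccc(OCCCCCC(=O)O)c1)C(=O)c1ccc(-c2cccc(Oc3ccccc3)c2)cc1` gives > 18700 nM in this assay, again a limit.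
Compound 3 `CCOC(=O)CCCCCOc1cccc(CN(C(=O)c2ccc(-c3cccc4ccccc34)cc2)C(C)C)c1` gives > 26000 nM in this assay, also a limit.

Of the three values shown, two sit at one limit of > 26000 nM in this assay, at which 2 of the 3 values shown sit, and one at another (the limit of > 18700 nM in this assay, at which 1 of the 3 values shown sits). Among the compounds with values here, compound 3 therefore stands at a limit and at no number; the only step between measured compounds, a step that the two limits leave unreadable from compound 1 to compound 3, is left unreadable by the two limits, so no measured step can be said to bear on the change at hand.

Compound 4 `CCOC(=O)CCCCCOc1cccc(CN(C(=O)c2ccc(-c3cccc(OC(C)C)c3)cc2)C(C)C)c1` is the unmeasured analogue of compound 3. It differs from compound 3 in one place: 3-isopropoxyphenyl in place of naphthalen-1-yl on an aromatic carbon.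

Within the data shown here, with every measured value at a limit, there is no step of known size to carry over, and the change of compound 3 to compound 4 is expected to show no effect beyond the scatter, with a step that the limit leaves unreadable from compound 3 to compound 4 in this assay. Compound 4 is therefore expected to give about 30000 nM, between 12000 nM and 90000 nM, in this assay, most likely again as a limit.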

Compound 4, half-maximal effective concentration: > 26000 nM
Compound 4: a limit, no number; the forecaster's own chance of this, stated with the estimate: 80%; the middle value does not contradict the limit.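

Compound 3 and compound 4 both stand at a limit and at no number in this assay, so 3-isopropoxyphenyl in place of naphthalen-1-yl gives no readable step between them: the limit of > 26000 nM in this assay, at which 3 of the 4 values shown sit.

The compounds shown leave open at what concentration any of them would reach the half-maximal effect in this assay, and whether this change alters that concentration at all.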